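This account rests on a few compounds, and the source may have more. Where it says the series, first, only, none or still open, it means among the compounds named here.

Compound 1 `N[C@@]1(C(=O)O)CN(C[C@@H]2COCCN2)C[C@@H]1CCCB(O)O` gives 10 nM in an assay for inhibition of arginase-1 (Homo sapiens), read by colorimetric assay, with a stated time of 60 min, in the presence of a further agent that is not named here; a lower number here means a stronger inhibitor, a higher number a weaker inhibitor; compound 2 `C[C@@H](N)CN1C[C@H](CCCB(O)O)[C@](N)(C(=O)O)C1` gives 16 nM.

Compound 2 stands at the higher of the two numbers, though the step of a 1.6-fold higher number from compound 1 to compound 2 (0.20 log units; within the scatter) is within the scatter. Compound 3 `N[C@@]1(C(=O)O)CN(Cc2ncccc2F)C[C@@H]1CCCB(O)O` carries 3-fluoropyridin-2-yl in place of 1-aminoethyl on a saturated chain carbon bound to an amine nitrogen in a ring. For the measured compounds named here, no measured step bears directly on this change: the one step known swaps one amine-bearing group for another and stays within the scatter, whereas here the amine leaves and an aromatic ring enters. A modest loss is therefore expected, with wide uncertainty, the step of a 1.9-fold higher number from compound 2 to compound 3 (0.27 log units; within the scatter) being the estimate. Compound 3 is expected to give 30 nM, in the range 8 nM to 150 nM.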

Compound 3, half-maximal inhibitory concentration: 670 nM
Compound 3: the middle estimate sits 22-fold (1.35 log units) below what was measured, and the stated range ends below it.
By their numbers in this assay, from the lowest: compounds 1 and 2 (each within the scatter of the next); then compound 3.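

In this assay the position on a saturated chain carbon bound to an amine nitrogen in a ring proves sensitive to its group: 3-fluoropyridin-2-yl gives a 42-fold higher number from compound 2 to compound 3 (1.62 log units; beyond the scatter) and also a 67-fold higher number from compound 1 to compound 3 (1.83 log units; beyond the scatter) against the group of compound 1. The earlier step, between two groups that both hold an amine, stayed within the scatter, so that swap was tolerated and this one was not. Nothing at hand explains the loss.

The compounds shown do not separate the fluorine, the aromatic ring and the loss of the amine. A plain pyridin-2-yl or a piperidine ring at this place would help to tell these apart.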